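The source may hold more compounds than are shown below. What is called first, only, known or untested is meant among the compounds shown, and "the series" means these compounds.

Compound 1 `Cn1c(/C=C2\SC(=O)N(CC(=O)Nc3cc(C(C)(C)C)on3)C2=O)nc2ccccc21` is the starting point, judged in a functional assay on A549 cells (Homo sapiens) for inhibition, read by MTT assay, with a stated time of 48 h; a lower number here means a stronger inhibitor, a higher number a weaker inhibitor. Among the compounds with values here, compound 1 gives 15300 nM, the lowest of the numbers measured so far. Compound 2 `CCn1c(/C=C2\SC(=O)N(CC(=O)Nc3cc(C(C)(C)C)on3)C2=O)nc2ccccc21` gives 44800 nM. The change behind that, methyl in place of hydrogen on a saturated chain carbon bound to an aromatic nitrogen, amounts to a 2.9-fold higher number from compound 1 to compound 2 (0.47 log units; beyond the scatter). Compound 3 `CC(C)n1c(/C=C2\SC(=O)N(CC(=O)Nc3cc(C(C)(C)C)on3)C2=O)nc2ccccc21` reaches only a limit of this assay, > 50000 nM. Compound 4 `Cn1c(/C=C2\SC(=O)N(CC(=O)N3CCCC3)C2=O)nc2ccccc21` differs from compound 1 at a different place: pyrrolidin-1-yl in place of (5-(tert-butyl)-1,2-oxazol-3-yl)amino on a carbonyl carbon. Within the data shown here, both measured steps concern the group on the aromatic nitrogen, so neither bears directly on this change, and the only guide is that the shared core already sits at weak inhibition. Compound 4 is therefore expected near 30000 nM, somewhere between 8000 nM and 100000 nM, an expected step of a 2.0-fold higher number from compound 1 to compound 4 (0.29 log units; within the scatter).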

Compound 4, half-maximal inhibitory concentration: > 50000 nM
Compound 4 ended at the assay's limit (the forecaster's own chance of this, stated with the estimate: 35%); middle value at least 1.6-fold (0.22 log units) away from the limit.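

Putting pyrrolidin-1-yl in place of (5-(tert-butyl)-1,2-oxazol-3-yl)amino on a carbonyl carbon gives an at least 3.2-fold higher number from compound 1 to compound 4 (0.51 log units; beyond the scatter), so inhibition depends on this position too, not only on the group on the aromatic nitrogen. The true size of this step stays unknown because compound 4 sits at a limit of the assay: the limit of > 50000 nM in this assay, at which 2 of the 4 values shown sit.

This one change alters the heavy-atom count, the aromatic ring and the hydrogen-bond donor together, and the compounds shown cannot separate these. As far as these compounds go, how a phenylamino group on that carbonyl carbon would compare remains open.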